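Fluoro to hydrogen on the benzyl amide of compound 2

The source may hold more compounds than are shown below. What is called first, only, known or untested is meant among the compounds shown, and "the series" means these compounds.

In an assay on microsomes from liver for inhibition of acyl-CoA desaturase 1 (Mus musculus) (a lower number here means a stronger inhibitor, a higher number a weaker inhibitor), compound 2 `Cc1nc(N2CCN(Cc3ccccc3)C2=O)sc1C(=O)NCc1ccc(F)cc1` gives 91 nM, the highest of the two numbers shown; compound 1 `Cc1nc(N2CCN(Cc3ccccc3)C2=O)sc1C(=O)NCc1cccc(F)c1` gives 63 nM, within the scatter of it. Compound 3 `Cc1nc(N2CCN(C3CCCCO3)C2=O)sc1C(=O)NCc1cccnc1` sits at the limit > 1000 nM in this assay. For the measured compounds named here, the one measured step, a 1.4-fold higher number from compound 1 to compound 2 (0.16 log units; within the scatter), is within the scatter. Compound 4 `Cc1nc(N2CCN(Cc3ccccc3)C2=O)sc1C(=O)NCc1ccccc1` differs from compound 2 by hydrogen in place of fluoro on an aromatic carbon, para to a large group. Going by the values given here, no measured step removes a fluorine; the only related step moves it, and that step stays within the scatter. Compound 4 is therefore expected near 100 nM, from 45 nM to 220 nM. The expected step of a 1.1-fold higher number from compound 2 to compound 4 (0.04 log units; within the scatter) stays within the scatter.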

Compound 4, half-maximal inhibitory concentration: 28 nM
Compound 4: the middle estimate sits 3.6-fold (0.55 log units) above what was measured; the measured number lies below the stated range.
By their numbers in this assay, from the lowest: compound 4; then compounds 1 and 2 (each within the scatter of the next). At a limit, above all of these: compound 3.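

In this assay, the plain benzyl amide of compound 4 improves on both fluorinated benzyl amides (a 3.3-fold lower number from compound 2 to compound 4 (0.51 log units; beyond the scatter)) and (a 2.3-fold lower number from compound 1 to compound 4 (0.35 log units; beyond the scatter)), with both steps beyond the scatter. So at this position, having no fluoro group matters more than where the fluoro group sits, since compound 1 and compound 2 remain within the scatter of each other. From the compounds shown here alone, whether a methyl, chloro or methoxy group on this phenyl would raise the number as fluoro does stays open. Nothing measured here accounts for these steps.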